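Swapping the dichlorophenyl of compound 2 for chlorophenyl

This account rests on a few compounds, and the source may have more. Where it says the series, first, only, none or still open, it means among the compounds named here.

Of the compounds shown here, two sharing one fused core have been measured in an assay on cells for displacement of a labelled ligand from adenosine receptor A3 (Homo sapiens), read by scintillation counting and radioligand binding, with a stated time of 180 min; a lower number here means a stronger inhibitor, a higher number a weaker inhibitor. Compound 1 `Clc1ccc(-c2nc(N3CCCCC3)c3nc[nH]c3n2)cc1` carries a 4-chlorophenyl group and a piperidine; in this assay compound 1 gives 7.94 nM. Compound 2 `CN1CCN(c2nc(-c3cc(Cl)ccc3Cl)nc3[nH]cnc23)CC1` carries a 2,5-dichlorophenyl group and a 4-methylpiperazin-1-yl group, and in this assay compound 2 gives 251 nM. Compound 2 thus stands at the higher of the two numbers, with compound 1 the stronger binder by a margin well beyond the scatter.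

Compound 3 `CN1CCN(c2nc(-c3ccc(Cl)cc3)nc3[nH]cnc23)CC1` keeps the 4-methylpiperazin-1-yl group of compound 2 and changes only the aryl group: 4-chlorophenyl in place of 2,5-dichlorophenyl on an aromatic carbon. For the measured compounds named here, no measured pair shows this exact step, so its size is a matter of expectation. Since compound 1, which carries the same 4-chlorophenyl group, gives 7.94 nM, while compound 2 gives 251 nM, the step of a 6.3-fold lower number from compound 2 to compound 3 (0.80 log units; beyond the scatter) is expected to run downward, well beyond the scatter. Compound 3 is accordingly estimated at 40 nM in this assay, with a plausible range from 10 nM to 160 nM.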

Compound 3, inhibition constant: 39.8 nM
Beside the measured number, compound 3's estimate is 1.0-fold (0.00 log units) above it; measured number inside the range.
By their numbers in this assay, from the lowest: compound 1; then compound 3; then compound 2.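

In this assay, with the 4-methylpiperazin-1-yl group held fixed, 4-chlorophenyl in place of 2,5-dichlorophenyl gives a 6.3-fold lower number from compound 2 to compound 3 (0.80 log units; beyond the scatter), so the aryl group on the aromatic carbon between two ring nitrogen atoms affects the number on its own. With the 4-chlorophenyl group held fixed, 4-methylpiperazin-1-yl in place of piperidin-1-yl gives a 5.0-fold higher number from compound 1 to compound 3 (0.70 log units; beyond the scatter), so the amine position also has its own effect, and each of the two places that separate compound 1 from compound 2 carries a step beyond the scatter. Nothing available bears on the reason for either step.

The aryl change moves one chlorine and removes another at once, so the compounds shown leave open how each chlorine placement contributes, a question that a plain phenyl, a 2-chlorophenyl or a 3-chlorophenyl group on the shared core could address. On the amine side, they also leave open whether the step follows from the ring nitrogen or from its methyl group, which a piperazin-1-yl or a morpholin-4-yl group could help separate.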